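Methoxy on the second aryl ring of compound 1

The source may hold more compounds than are shown below. What is called first, only, known or untested is meant among the compounds shown, and "the series" means these compounds.

Three members of the series have numbers in a functional assay on U-87MG ATCC cells for antiproliferative activity against U-87 MG (Homo sapiens), read by MTT assay, with a stated time of 48 h, tested at 5 uM; on this read-out lower numbers stand for a stronger effect and higher numbers for a weaker effect at the one concentration tested. Compound 1 `Cc1nc(-c2ccc(Cl)cc2)sc1C(=O)CSc1nc(-c2ccccc2)c(C#N)c(=O)[nH]1` gives 88.9%; compound 2 `Cc1nc(-c2ccccc2)sc1C(=O)CSc1nc(-c2ccccc2)c(C#N)c(=O)[nH]1` gives 92.1%; compound 3 `COc1ccc(-c2nc(C)c(C(=O)CSc3nc(-c4ccccc4)c(C#N)c(=O)[nH]3)s2)cc1` gives 99%. Compound 1 holds the lowest of the three numbers, with compound 2 nearest and compound 3 furthest: the step of a number 3.2 percentage points higher from compound 1 to compound 2 (within the scatter) lies within the scatter, the step of a number 10.1 percentage points higher from compound 1 to compound 3 (beyond the scatter) lies beyond it, and the step of a number 6.9 percentage points higher from compound 2 to compound 3 (within the scatter) lies within it.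

Compound 4 `COc1cccc(-c2nc(SCC(=O)c3sc(-c4ccc(Cl)cc4)nc3C)[nH]c(=O)c2C#N)c1` is unmeasured. Against compound 1 the difference is methoxy in place of hydrogen on an aromatic carbon. The measured steps all exchange a group on an aromatic carbon elsewhere in the shared core, so none matches this change in place. For the measured compounds named here, they still bear on it: the two steps that introduce methoxy both move the number upward, one beyond the scatter, one within it, and no methoxy-bearing compound among the three sits below compound 1. A small upward step in this assay is therefore expected, with no change beyond the scatter equally possible.

Compound 4 is estimated at 94%, in a range from 85% to 103%. This corresponds to an expected a number 5.1 percentage points higher from compound 1 to compound 4 (within the scatter).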

Compound 4, a percentage reported as activity, at one concentration (the size of the read-out at that concentration, not a potency): 96.6%
The estimate for compound 4 lay 2.6 percentage points below the measured number, and the stated range covers the measured number.
By their numbers in this assay, from the lowest: compounds 1, 2, 4 and 3 (each within the scatter of the next, the first and the last beyond it).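

Phenyl to 3-methoxyphenyl, on the carbon meta to a large group, is the first change shown on this ring, and in this assay it comes out as a number 7.7 percentage points higher from compound 1 to compound 4 (within the scatter). This position therefore shows no step beyond the scatter for methoxy in place of hydrogen, on a core that keeps the chloro group on its other aryl ring. The exchange now has a reading at two places in the series, and the two steps agree, though neither can be separated from the scatter on its own: the same change on two cores in this assay, a number 6.9 percentage points higher (within the scatter) from compound 2 to compound 3 and a number 7.7 percentage points higher (within the scatter) from compound 1 to compound 4, 0.8 percentage points apart, within the scatter of two such steps

Going by these compounds, whether an amine, a hydroxyl group or a carboxylic acid in place of the same hydrogen would read any differently stays open, as does methoxy on the other carbons of this ring. Every number here also comes from a single concentration, so the series shows no potency for any of these compounds, and none of the steps shown runs toward a stronger effect than that of compound 1.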